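A few compounds are considered here, and "the series" means these few. Any claim that something is new, unique, unknown or untested is made for them only; others in the source may bear on it.

Three compounds share one core and differ only in the group on a saturated chain carbon bound to a saturated ring carbon. In a functional assay on HFF cells (Homo sapiens) for cytotoxicity (a higher number here means a weaker inhibitor, a lower number a stronger inhibitor), compound 1 (`CC(=O)OC1C(CCl)OC(n2c(Cl)nc3cc(Cl)c(Cl)cc32)C1OC(C)=O`), which carries chloro at that place, gives 32000 nM. Compound 2 (`CC(=O)OC1C(CBr)OC(n2c(Cl)nc3cc(Cl)c(Cl)cc32)C1OC(C)=O`), which carries bromo, gives 32000 nM. Compound 3 (`CC(=O)OC1C(CN=[N+]=[N-])OC(n2c(Cl)nc3cc(Cl)c(Cl)cc32)C1OC(C)=O`), which carries azido, gives 32000 nM, so it stands level with the other two.

The next compound, compound 4 (`CSCC1OC(n2c(Cl)nc3cc(Cl)c(Cl)cc32)C(OC(C)=O)C1OC(C)=O`), has methylsulfanyl in place of azido at the same place: methylsulfanyl in place of azido on a saturated chain carbon bound to a saturated ring carbon. The most relevant evidence comes from the measured swaps at this position. Replacing chloro with bromo gives no change at the digits printed from compound 1 to compound 2 (within the scatter), and replacing chloro with azido gives no change at the digits printed from compound 1 to compound 3 (within the scatter). Among the compounds with values here, none of the measured compounds carries methylsulfanyl, however, so the new group itself is untested and the forecast is an extrapolation. Resting on no change at the digits printed from compound 2 to compound 3 (within the scatter) and the two other flat steps, no change beyond the scatter is expected in this assay. The estimated step is no change at the digits printed from compound 3 to compound 4 (within the scatter). The expected value for compound 4 is 32000 nM, with an estimated range of 16000 nM to 64000 nM.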

Compound 4, half-maximal inhibitory concentration: 32000 nM
Compound 4: middle estimate and measured number agree at the digits printed; low and high end bracket the measured number.
By their numbers in this assay, from the lowest: compounds 1, 2, 3 and 4 (each within the scatter of the next).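

In this assay, putting methylsulfanyl in place of azido gives no change at the digits printed from compound 3 to compound 4 (within the scatter), and the comparisons with the two halogen compounds give no change at the digits printed from compound 2 to compound 4 (within the scatter) and no change at the digits printed from compound 1 to compound 4 (within the scatter). Within the data shown here, until now this place had carried only chloro, bromo and azido, so compound 4 adds the first group here that contains sulfur and carbon, and it stands level with the others even though it has two heavy atoms and no double bonds, where azido has three nitrogens and two double bonds. Across these four compounds, then, the assay does not separate the groups on a saturated chain carbon bound to a saturated ring carbon, and none of the four goes against that flat picture.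

No measurement shown here accounts for why the numbers stay level. From the compounds shown here alone, it remains open whether an amine, a carboxylic acid or a longer chain such as butylsulfanyl at this place would also stay level, or whether one of them would finally move the number away from that of compound 4.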